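Swapping the urea aryl group on a shared core

The compounds below may be only part of what the source reports. "The series", "measured", "known", "first", "only" and "open" are said of these compounds alone.

Measured so far:
compound 2, `COc1ccc(NC(=O)Nc2nc(Sc3c[nH]c4ccccc34)cc(N3CCCCC3)n2)cc1`, 7260 nM
compound 1, `Cc1cc(Cl)ccc1NC(=O)Nc1nc(Sc2c[nH]c3ccccc23)cc(N2CCN(Cc3ccccc3)CC2)n1`, 22100 nM
compound 3, `COc1ccc(NC(=O)Nc2nc(Sc3c[nH]c4ccccc34)cc(N3CCN(c4ccccn4)CC3)n2)cc1`, 28400 nM

Of the compounds shown here, three sharing one core have been tested in a functional assay on MDA-MB-231 cells (Homo sapiens) for inhibition, with a stated time of 72 h; a lower number here means a stronger inhibitor, a higher number a weaker inhibitor. Compound 2 gives the lowest number of the three, and both of its neighbours lie beyond the scatter: compound 1 sits at 22100 nM and compound 3 at 28400 nM. For the measured compounds named here, the one single-point step among them, a 3.9-fold higher number from compound 2 to compound 3 (0.59 log units; beyond the scatter), concerns the saturated ring on the core and not the aryl group on the urea.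

Compound 4, `Cc1ccc(C)c(NC(=O)Nc2nc(Sc3c[nH]c4ccccc34)cc(N3CCCCC3)n2)c1`, is the next compound to be measured. It differs from compound 2 in one place: 2,5-dimethylphenyl in place of 4-methoxyphenyl on an amide-type nitrogen. Going by the values given here, no measured step touches this part of the molecule. Compound 1 also carries a differently substituted phenyl on the urea, but it differs from compound 2 in a second place as well. For that reason the gap between compound 2 at 7260 nM and compound 1 at 22100 nM cannot be read as the effect of the aryl change alone.

With nothing direct to lean on, the expectation is a step of a 1.2-fold higher number from compound 2 to compound 4 (0.09 log units; within the scatter), that is, no shift beyond the scatter. Compound 4 is therefore estimated at 9000 nM, within a range from 3000 nM to 27000 nM.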

Compound 4, half-maximal inhibitory concentration: 5940 nM
Beside the measured number, compound 4's estimate is 1.5-fold (0.18 log units) above it; low and high end bracket the measured number.
By their numbers in this assay, from the lowest: compounds 4 and 2 (each within the scatter of the next); then compounds 1 and 3 (each within the scatter of the next).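

In this assay, for the compounds shown here, the aryl group on the urea can be exchanged with no change beyond the scatter: putting 2,5-dimethylphenyl in place of 4-methoxyphenyl on an amide-type nitrogen gives a 1.2-fold lower number from compound 2 to compound 4 (0.09 log units; within the scatter) and is the first step that isolates this position. Both groups have 8 heavy atoms and one six-membered aromatic ring of carbon only, but 4-methoxyphenyl has 1 hydrogen-bond acceptor and 2,5-dimethylphenyl has 0, so with the piperidin-1-yl group held constant, this pair does not need that acceptor to stay at the same level. No available measurement explains why these two aryl groups give such similar numbers.

On these data alone, it remains open whether this exchange would behave the same way with a different group on the core, such as the 4-(pyridin-2-yl)piperazin-1-yl group of compound 3. Also open, as far as these compounds go, is whether an unsubstituted phenyl, or a phenyl carrying a carboxylic acid or an amine, would stay within the scatter of compound 2 and compound 4.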